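Extending methyl to ethyl on the shared core

A few compounds are considered here, and "the series" means these few. Any claim that something is new, unique, unknown or untested is made for them only; others in the source may bear on it.

Values so far in an ADME assay on Vero cells (Chlorocebus sabaeus) for cytotoxicity, read by luminescence and CellTiter-Glo, with a stated time of 3 days (on this read-out lower numbers stand for higher toxicity in this test and higher numbers for lower toxicity in this test), and the compound still open:
compound 1 `[N-]=[N+]=Nc1c(F)c(=O)[nH]c(=O)n1[C@@H]1O[C@H](CO)[C@@H](O)[C@H]1O` gives 47000 nM
compound 2 `Cc1c(F)c(=O)[nH]c(=O)n1[C@@H]1O[C@H](CO)[C@@H](O)[C@H]1O` gives 9040 nM
compound 3 `CCc1c(F)c(=O)[nH]c(=O)n1[C@@H]1O[C@H](CO)[C@@H](O)[C@H]1O` not yet measured

In this assay compound 2 at 9040 nM holds the lower of the two numbers. The next change is methyl in place of hydrogen on a saturated chain carbon bound to an aromatic carbon and amounts to methyl in place of hydrogen on a saturated chain carbon bound to an aromatic carbon, or methyl to ethyl. Among the measured compounds shown here, the only measured step that bears on it is a 5.2-fold lower number from compound 1 to compound 2 (0.72 log units; beyond the scatter) for methyl in place of azido on an aromatic carbon. That step swaps a different group, so it gives a rough scale only and no direction. For the measured compounds named here, no measured step lengthens the chain. A small change is therefore expected, and the expected size is a 1.2-fold higher number from compound 2 to compound 3 (0.09 log units; within the scatter) in this estimate. Compound 3 is estimated at 11000 nM with an expected range from 4000 nM to 35000 nM as the working figure.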

Compound 3, half-maximal cytotoxic concentration: > 200000 nM
Compound 3: no number, only a limit; the forecaster's own chance of this, stated with the estimate: 10%; middle value at least 18-fold (1.25 log units) from the limit.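

In this assay compound 3 gives > 200000 nM, a limit of the assay and not a number. The methyl to ethyl change alone gives an at least 22-fold higher number from compound 2 to compound 3 (1.34 log units; beyond the scatter), so a single added methyl at this position, on a saturated chain carbon bound to an aromatic carbon, shifts the read-out towards lower toxicity in this test by a large step. Ethyl in place of azido gives an at least 4.2-fold higher number from compound 1 to compound 3 (0.62 log units; beyond the scatter), which leaves compound 2, with methyl, as the one with the lowest number of the three, and the order does not follow chain length from methyl to ethyl alone.

Going by these compounds, the full size of both new steps stays open, since compound 3 has only a limit. Also open, on these data alone, is whether a longer chain such as propyl, or an amine or a carboxylic acid on this carbon, keeps the number this high.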